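Moving the chlorine on the triazole-bound phenyl ring

The source may report more compounds than this note shows. Statements on the series, on what has been measured and on what is new or still open speak of the compounds shown alone.

Measured compounds:
- compound 1, `O=c1[nH]cc(S(=O)(=O)Nc2cccc(-c3cn(-c4ccccc4)nn3)c2)c(=O)[nH]1`, 12700 nM
- compound 2, `O=c1[nH]cc(S(=O)(=O)Nc2cccc(-c3cn(-c4ccc(F)cc4)nn3)c2)c(=O)[nH]1`, > 20000 nM
- compound 3, `O=c1[nH]cc(S(=O)(=O)Nc2cccc(-c3cn(-c4ccccc4Cl)nn3)c2)c(=O)[nH]1`, 2730 nM

These three share one core and differ only in the phenyl ring on the triazole nitrogen. In a functional assay on A549 cells (Homo sapiens) for antiproliferative activity, read by MTT assay, with a stated time of 24 h (on this read-out lower numbers stand for stronger inhibition and higher numbers for weaker inhibition), compound 1 gives 12700 nM. For compound 2 the value > 20000 nM is a limit of the assay rather than a number. Compound 3 gives 2730 nM, the lowest number among the measured compounds; the step of a 4.7-fold lower number from compound 1 to compound 3 (0.67 log units; beyond the scatter) lies beyond the scatter, as does an at least 7.3-fold lower number from compound 2 to compound 3 (0.86 log units; beyond the scatter). The step of an at least 1.5-fold higher number from compound 1 to compound 2 (0.19 log units; that floor lies within the scatter) has a floor that lies within the scatter.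

Compound 4, `O=c1[nH]cc(S(=O)(=O)Nc2cccc(-c3cn(-c4ccc(Cl)cc4)nn3)c2)c(=O)[nH]1`, has not yet been measured. It differs from compound 3 by 4-chlorophenyl in place of 2-chlorophenyl on an aromatic nitrogen. Among the measured compounds shown here, two measured steps bear on this. Compound 1 to compound 3 shows that a chlorine on the 2-chlorophenyl ring lowers the number; compound 1 to compound 2 shows that a fluorine on the 4-fluorophenyl ring does not, and may raise it, given (the limit of > 20000 nM in this assay, at which 1 of the 3 values shown sits). Compound 4 is therefore expected to lose most of the gain seen for compound 3, with a step of about a 4.4-fold higher number from compound 3 to compound 4 (0.64 log units; beyond the scatter) in this assay. The estimate for compound 4 is 12000 nM, within a range of 4000 nM to 30000 nM.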

Compound 4, half-maximal inhibitory concentration: 1730 nM
The estimate for compound 4 lay 6.9-fold (0.84 log units) above the measured number, outside the stated range (below it).
By their numbers in this assay, from the lowest: compounds 4 and 3 (each within the scatter of the next); then compound 1. At a limit, above all of these: compound 2.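

In this assay, moving the chlorine leaves no difference that can be read: a 1.6-fold lower number from compound 3 to compound 4 (0.20 log units; within the scatter), so 4-chlorophenyl serves as well as 2-chlorophenyl on the triazole nitrogen, and the lower number of compound 3 does not depend on that one placement. Chloro in place of hydrogen now lowers the number with either group, with a 4.7-fold lower number from compound 1 to compound 3 (0.67 log units; beyond the scatter) and a 7.3-fold lower number from compound 1 to compound 4 (0.87 log units; beyond the scatter), both beyond the scatter. With the substituent's placement in the name held the same, as 4-fluorophenyl and 4-chlorophenyl, the identity of the halogen separates the compounds, with an at least 11-fold lower number from compound 2 to compound 4 (1.06 log units; beyond the scatter), and this step is only a floor, since the value of compound 2 is a limit of the assay: the limit of > 20000 nM in this assay, at which 1 of the 4 values shown sits.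

As far as these compounds go, whether bromo, methyl or an amine in place of the chlorine of compound 4 would keep its number remains open, as does what a carboxylic acid would do there. All four values also come from one cell line at one stated time, so whether the same pattern holds in other cells or at other times cannot be told from these compounds.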